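The source may report more compounds than this note shows. Statements on the series, on what has been measured and on what is new or still open speak of the compounds shown alone.

Among the compounds with values here, compound 1 `CC1=C(/C=C/C(C)=C/C=C/C(C)=C\C(=O)NCc2ccc(F)cc2)C(C)(C)CCC1n1ccnc1` is the stronger of the two compounds measured so far in a functional assay on SK-BR-3 cells (Homo sapiens) for inhibition, read by MTT assay; a lower number here means a stronger inhibitor of growth, a higher number a weaker inhibitor of growth: compound 1 gives 5500 nM. Compound 2 `CC1=C(/C=C/C(C)=C/C=C/C(C)=C\C(=O)Nc2ccccc2)C(C)(C)CC=C1c1cccnc1` differs from compound 1 in several places. In this assay compound 2 gives 47400 nM, a number that lies beyond the usual scatter on the weaker side of compound 1. Compound 3 `CC1=C(/C=C/C(C)=C/C=C/C(C)=C\C(=O)Nc2ccc(F)cc2)C(C)(C)CCC1n1ccnc1` is a close relative of compound 1, and the two differ in a single place: 4-fluorophenyl in place of 4-fluorobenzyl on an amide-type nitrogen. Within the data shown here, no measured pair isolates this change, so there is no direct guide to its effect. Because compound 1 stands at 5500 nM, the expected step is modest, a 1.5-fold higher number from compound 1 to compound 3 (0.16 log units; within the scatter), leaning toward a somewhat weaker inhibitor of growth. Compound 3 is therefore estimated at 8000 nM in this assay, with a likely range from 2500 nM to 25000 nM.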

Compound 3, concentration for 50% growth inhibition: 25100 nM
For compound 3 the middle estimate is 3.1-fold (0.50 log units) below the measured one; the whole stated range lies below it.
By their numbers in this assay, from the lowest: compound 1; then compounds 3 and 2 (each within the scatter of the next).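

Within the data shown here, compound 1 and compound 3 form the first measured pair that differs in a single place, giving a direct reading of the group on the amide-type nitrogen: in this assay, replacing 4-fluorobenzyl with 4-fluorophenyl gives a 4.6-fold higher number from compound 1 to compound 3 (0.66 log units; beyond the scatter). Both groups hold a six-membered aromatic ring of carbon and a fluorine, and neither brings hydrogen-bond donors or acceptors, yet the step lies beyond the scatter, so growth inhibition at this position responds to even this small edit. No measurement here explains why the number rises.

Still open, from the compounds shown here alone, is whether a longer chain, as in 2-(4-fluorophenyl)ethyl on the amide-type nitrogen, would give a lower number than compound 1. Also open, going by these compounds, is whether the same step would appear with chlorine in place of the fluorine on both groups.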